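Swapping chloromethyl for 4-methoxyphenyl: cytotoxicity outlook

This account rests on a few compounds, and the source may have more. Where it says the series, first, only, none or still open, it means among the compounds named here.

Measured compounds:
- compound 1 `C/C(=N\Nc1nc(CCl)cs1)c1ccc(Cl)c(Cl)c1`: > 50000 nM
- compound 2 `C/C(=N\Nc1nc(-c2ccc(Cl)c(Cl)c2Cl)cs1)c1ccc(Cl)c(Cl)c1`: 21300 nM
- compound 3 `C/C(=N\Nc1nc(-c2ccc(Br)cc2)c(C)s1)c1ccc(Cl)c(Cl)c1`: > 50000 nM

Of the compounds shown here, three sharing a core have been tested in an ADME assay on J774 cells (Mus musculus) for cytotoxicity, read by resazurin assay, with a stated time of 72 h; on this read-out higher numbers stand for lower toxicity in this test and lower numbers for higher toxicity in this test. Compound 1 gives > 50000 nM, which is a limit of the test rather than a number. Compound 3 likewise gives > 50000 nM, again only a limit. Compound 2, by contrast, gives a measured value of 21300 nM in this assay. Compound 1 therefore stands at the limit shared by the limit of > 50000 nM in this assay, at which 2 of the 3 values shown sit, and nothing more precise is known about it.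

The compound now under consideration is compound 4 `COc1ccc(-c2csc(N/N=C(\C)c3ccc(Cl)c(Cl)c3)n2)cc1`. It differs from compound 1 in one place: 4-methoxyphenyl in place of chloromethyl on an aromatic carbon. Among the compounds with values here, no two of the measured compounds differ in exactly one place, so no measured step is available to guide the expectation. Of the two measured compounds carrying an aryl group at that position, compound 3 sits at the limit while compound 2 gives a number somewhat below it.

For compound 4 the expected result is 45000 nM, within a range from 18000 nM to 100000 nM. The expected step of an at least 1.1-fold lower number from compound 1 to compound 4 (0.04 log units; that floor lies within the scatter) is none beyond the scatter, with a fair chance that this assay again reports only a limit.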

Compound 4, half-maximal cytotoxic concentration: > 50000 nM
Compound 4 gave a limit, no number; the forecaster's own chance of this, stated with the estimate: 55%; middle value at least 1.1-fold (0.04 log units) from the limit.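

In this assay compound 4, like compound 1, gives only a limit of the test and not a number, so no step between the two can be read: the limit of > 50000 nM in this assay, at which 3 of the 4 values shown sit.

The compounds shown leave open whether 4-methoxyphenyl in place of chloromethyl changes the half-maximal cytotoxic concentration at all, and by how much.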